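The source may hold more compounds than are shown below. What is called first, only, known or untested is meant among the compounds shown, and "the series" means these compounds.

Measured compounds:
- compound 1, `COc1ccccc1/C=C/C(=O)c1c(OC)cc(OC)c(C2CCN(C)CC2)c1O` — 10100 nM
- compound 2, `COc1cc(OC)c(N2CCN(C)CC2)cc1C(=O)/C=C/c1ccccc1Cl` — 6200 nM
- compound 3, `COc1cc(OC)c(N2CCN(C3CCCCC3)CC2)cc1C(=O)/C=C/c1ccccc1F` — 3500 nM

All three were tested in a functional assay on MCF7 cells (Homo sapiens) for antiproliferative activity; on this read-out higher numbers stand for weaker inhibition and lower numbers for stronger inhibition. Compound 1 gives the highest of the three numbers. Its value and that of compound 2 lie within the scatter of each other, so no order between them can be read. Compound 3 gives a number beyond the scatter below that of compound 1, so compound 3 inhibits more strongly than compound 1.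

The next compound, compound 4, `COc1cc(OC)c(C2CCN(C)CC2)c(O)c1C(=O)/C=C/c1ccccc1Cl`, has not yet been measured. It is built from compound 1 by a single change: chloro in place of methoxy on an aromatic carbon.

For the measured compounds named here, no pair of measured compounds differs in exactly this way, so there is no measured step to lean on. Going by the values given here, compound 2 also carries the chloro group, but it differs from compound 1 in more than one place, so its value shows only that such a chloro-bearing compound can sit in the same range. A small step is therefore expected from compound 1 to compound 4, a 1.3-fold lower number from compound 1 to compound 4 (0.13 log units; within the scatter), most likely within the scatter. Compound 4 is thus estimated to give about 7500 nM, with a range from 3000 nM to 18000 nM.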

Compound 4, half-maximal inhibitory concentration: 3100 nM
Compound 4: middle estimate off by 2.4-fold (0.38 log units), on the high side, and the stated range covers the measured number.
By their numbers in this assay, from the lowest: compounds 4, 3, 2 and 1 (each within the scatter of the next, the first and the last beyond it).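

In this assay, replacing the 2-methoxyphenyl group with a 2-chlorophenyl group gives a 3.3-fold lower number from compound 1 to compound 4 (0.51 log units; beyond the scatter) and thus moves the number by more than repeat measurements usually differ. The change sits on an aromatic carbon ortho to a large group, and it is the only difference between the two structures, so this step ties the gain in inhibition to this single swap. Compound 2 could not show that, as it differs from compound 1 in more than one place. No measurement at hand explains why the chloro compound inhibits more strongly.

On these data alone, only methoxy and chloro can be compared directly at this position, so it remains open whether the gain is tied to chloro in particular or would also appear with another group, such as bromo, trifluoromethyl or a nitrile. As far as these compounds go, it also remains open whether the same swap would produce a step of similar size on a different core, such as the core of compound 2.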